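The source may report more compounds than this note shows. Statements on the series, on what has been measured and on what is new or still open speak of the compounds shown alone.

Of the compounds shown here, three have been measured in an assay on HEK293 cells for agonist activity at transient receptor potential cation channel subfamily M member 8 (Homo sapiens), read by fluorescence and calcium flux, with a stated time of 15 min; on this read-out lower numbers stand for an effect already at smaller amounts and higher numbers for an effect only at larger amounts of compound. Compound 2 `Cc1ccc(OCC(=O)N(Cc2cccs2)c2c(C)n[nH]c2C)cc1` gives 0.3 nM, the lowest of the two numbers reported. Compound 1 `CCN(Cc1ccco1)C(=O)COc1ccc(C)cc1` gives 489 nM, a far higher number, beyond the usual scatter. Compound 3 `Cc1ccc(OC2CCN(Cc3cccs3)C2=O)cc1` gives "not active" (no number reported), with no number attached. Compound 4 `CCCN(Cc1cccs1)C(=O)COc1ccc(C)cc1` has not yet been measured; it differs from compound 2 in one place: propyl in place of 3,5-dimethyl-1H-pyrazol-4-yl on an amide-type nitrogen. Within the data shown here, no step between measured compounds with a single change is known. Compound 1 also carries a chain rather than a ring on the amide-type nitrogen, and because compound 1 gives 489 nM, compound 4 is expected to land near it rather than near compound 2. The expected step is a 1000-fold higher number from compound 2 to compound 4 (3.00 log units; beyond the scatter), a large rise well beyond the scatter. Compound 4 is estimated at 300 nM, within a range from 50 nM to 2000 nM.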

Compound 4, half-maximal effective concentration: 40 nM
Compound 4: middle estimate off by 7.5-fold (0.88 log units), on the high side; measured number outside the range, below it.
By their numbers in this assay, from the lowest: compound 2; then compound 4; then compound 1.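

Replacing 3,5-dimethyl-1H-pyrazol-4-yl with propyl on the amide-type nitrogen gives a 130-fold higher number from compound 2 to compound 4 (2.12 log units; beyond the scatter) in this assay, so this single change has a large effect on the read-out. Even so, the ring is not needed for a measurable effect, as compound 4 with its plain chain still gives 40 nM in this read-out. No measurement shown here explains the size of this step.

Still open, from the compounds shown here alone, is whether a phenyl ring at this place would keep a number as low as that of compound 2. Also open, going by these compounds, is how a longer chain, such as butyl or pentyl, would compare with propyl.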